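From oxan-3-yl to 1H-indazol-4-yl on the shared core

The source may hold more compounds than are shown below. What is called first, only, known or untested is meant among the compounds shown, and "the series" means these compounds.

In a physicochemical assay for solubility (on this read-out higher numbers stand for higher solubility and lower numbers for lower solubility), compound 2 (`CNC(=O)c1cc(C(=O)NC2CC2)cn(CC2CCCOC2)c1=O`) gives >= 131 ug/mL as a limit, not a number. Compound 1 (`CNC(=O)c1cc(C(=O)NC2CC2)cn(Cc2ccc(F)cc2)c1=O`) also gives only a limit, >= 162 ug/mL in this read-out. Within the data shown here, the sole measured step is a step that the two limits leave unreadable from compound 1 to compound 2 and offers no size to carry forward. Compound 3 (`CNC(=O)c1cc(C(=O)NC2CC2)cn(Cc2cccc3[nH]ncc23)c1=O`) differs from compound 2 by 1H-indazol-4-yl in place of oxan-3-yl on a saturated chain carbon bound to an aromatic nitrogen in one place. The expected step, an at least 1.8-fold lower number from compound 2 to compound 3 (0.27 log units; that floor lies within the scatter) in this assay, is a downward estimate resting on the structural change alone. For compound 3 the estimate is 70 ug/mL with an expected range of 20 ug/mL to 200 ug/mL around it.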

Compound 3, solubility: 10 ug/mL
Compound 3: the middle estimate sits 7.0-fold (0.85 log units) above what was measured; measured number below the stated range.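

In this assay, the position on a saturated chain carbon bound to an aromatic nitrogen gives its first readable change, with an at least 13-fold lower number from compound 2 to compound 3 (1.11 log units; beyond the scatter) for 1H-indazol-4-yl against oxan-3-yl, and an at least 16-fold lower number from compound 1 to compound 3 (1.20 log units; beyond the scatter) against 4-fluorophenyl. The step between compound 1 and compound 2 cannot be read, so only 1H-indazol-4-yl separates from the other groups here. Both sizes are floors because each starting value is a limit, as for compound 2: the limit of >= 131 ug/mL in this assay, at which 1 of the 3 values shown sits.

Which part of 1H-indazol-4-yl carries the step stays open. So does whether an amine or a carboxylic acid on this carbon would stay near those limits.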